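The source may hold more compounds than are shown below. What is called first, only, known or untested is meant among the compounds shown, and "the series" means these compounds.

Series notes, antiproliferative data. Compound 1 `Cc1nn(C)c(Oc2ccc(F)cc2)c1/C=N\OCc1c(Cl)c(-c2ccc(F)cc2)nn1C` and compound 2 `Cc1nn(C)c(Oc2ccc(F)cc2)c1/C=N\OCc1c(Cl)c(-c2ccc(Cl)cc2)nn1C` share one core and differ only in the halogen on the aromatic carbon. In a functional assay on HCT-116 cells (Homo sapiens) for antiproliferative activity, read by MTT assay, with a stated time of 72 h (a higher number here means a weaker inhibitor, a lower number a stronger inhibitor), compound 1 gives 8020 nM, and compound 2 gives 7250 nM. The step of a 1.1-fold lower number from compound 1 to compound 2 (0.04 log units; within the scatter) stays within the scatter. Among the measured compounds shown here, compound 2 thus holds the lowest of the two numbers so far, but compound 1 sits close enough that no order between them can be read.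

Compound 3 `COc1ccc(Oc2c(/C=N\OCc3c(Cl)c(-c4ccc(Cl)cc4)nn3C)c(C)nn2C)cc1` is the next candidate. Relative to compound 2 the change is methoxy in place of fluoro on an aromatic carbon. For the measured compounds named here, no measured step touches a methoxy at this position, and the only step in hand is the halogen exchange between compound 1 and compound 2, which moved nothing beyond the scatter. With no bearing evidence, the expectation for compound 3 in this assay is a step of a 1.0-fold higher number from compound 2 to compound 3 (0.01 log units; within the scatter) that stays inside the scatter. Compound 3 is therefore estimated at 7500 nM, within 3000 nM to 18000 nM.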

Compound 3, half-maximal inhibitory concentration: 1260 nM
Estimate against measurement, compound 3: 6.0-fold (0.77 log units) above; measured number outside the range, below it.
By their numbers in this assay, from the lowest: compound 3; then compounds 2 and 1 (each within the scatter of the next).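

In this assay, among the compounds shown here, the change from 4-fluorophenoxy to 4-methoxyphenoxy gives a 5.8-fold lower number from compound 2 to compound 3 (0.76 log units; beyond the scatter), the first step to lie beyond the scatter. This aromatic carbon, para to a large group, therefore responds to what it carries, whereas the halogen exchange elsewhere in the molecule, a 1.1-fold lower number from compound 1 to compound 2 (0.04 log units; within the scatter), showed no readable change. Nothing in hand bears on why methoxy in place of fluoro moves the number here.

The compounds shown leave open whether the step belongs to methoxy alone or would extend to a hydroxyl, an ethoxy or a dimethylamino group at the same carbon. Also open, from the compounds shown here alone, is whether the same exchange carries over when the halogen on the other aromatic ring is fluoro, as in compound 1, rather than chloro.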